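Trifluoromethyl to methoxy on the phenyl group

This account rests on a few compounds, and the source may have more. Where it says the series, first, only, none or still open, it means among the compounds named here.

Values in a functional assay (aorta) with Rattus norvegicus as the target (on this read-out lower numbers stand for stronger inhibition and higher numbers for weaker inhibition), for the compounds measured so far
- Compound 1 (`CC1(C)Oc2ccc(C#N)cc2[C@@H](/N=C(\NC#N)Nc2ccccc2)[C@@H]1O`) gives 1400 nM; 1300 nM (2 entries)
- Compound 2 (`CC1(C)Oc2ccc(C#N)cc2[C@@H](/N=C(\NC#N)Nc2cccc(Cl)c2)[C@@H]1O`) gives 600 nM
- Compound 3 (`CC1(C)Oc2ccc(C#N)cc2[C@@H](/N=C(\NC#N)Nc2ccc(C(F)(F)F)cc2)[C@@H]1O`) gives 8100 nM

Compound 3 carries the highest number of the three, and a 14-fold higher number from compound 2 to compound 3 (1.13 log units; beyond the scatter) marks the gap to the closest single value. Compound 4 (`COc1ccc(N/C(=N/[C@@H]2c3cc(C#N)ccc3OC(C)(C)[C@H]2O)NC#N)cc1`) keeps the shared core and places methoxy in place of trifluoromethyl on an aromatic carbon, para to a large group (methoxy in place of trifluoromethyl on an aromatic carbon). Going by the values given here, only one measured step touches this group, and it is large and beyond the scatter. It swaps a different group at a different place, however, so it shows that the phenyl substituent can matter without measuring methoxy itself. Compound 1, which has plain phenyl, offers a steadier reference, since its two entries agree closely (the several entries of compound 1 in this assay, 1400 nM; 1300 nM (2 entries)). Among the compounds with values here, the estimate therefore leans from compound 3 towards compound 1, though no methoxy compound has yet been measured. The expected change in this assay is a 3.2-fold lower number from compound 3 to compound 4 (0.51 log units; beyond the scatter), towards a lower number. The estimated value for compound 4 is 2500 nM, with an expected range from 800 nM to 8000 nM.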

Compound 4, half-maximal inhibitory concentration: 32500 nM
Beside the measured number, compound 4's estimate is 13-fold (1.11 log units) below it, and the stated range ends below it.
By their numbers in this assay, from the lowest: compound 2; then compound 3; then compound 4.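

In this assay, replacing trifluoromethyl with methoxy brings a 4.0-fold higher number from compound 3 to compound 4 (0.60 log units; beyond the scatter), so a second group at this place also reads well above plain phenyl, where compound 1 gives 1400 nM; 1300 nM (2 entries). Measured against the 3-chlorophenyl group, the 4-methoxyphenyl group brings a 54-fold higher number from compound 2 to compound 4 (1.73 log units; beyond the scatter), showing how far the choice of phenyl substituent can move this read-out. These gaps are much wider than the spread between repeat readings: the several entries of compound 1 in this assay, 1400 nM; 1300 nM (2 entries)

The compounds shown cannot separate the effect of a group from the effect of its place on the phenyl ring, as none of these groups appears at two places. On these data alone, it also remains open how a fluorine, an amine or a carboxylic acid at this place would compare with trifluoromethyl and methoxy.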